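Cap variation in the trifluoromethyl ketone hydrate series

The source may report more compounds than this note shows. Statements on the series, on what has been measured and on what is new or still open speak of the compounds shown alone.

Of the compounds shown here, three sharing the same linker and hydrate warhead have been measured in an assay on isolated protein for inhibition of protein deacetylase HDAC6 (Homo sapiens), read by chemiluminescence, with a stated time of 3 h; a higher number here means a weaker inhibitor, a lower number a stronger inhibitor. Compound 1 `COc1ccc(NC(=O)CCCCCCNC(=O)C(O)(O)C(F)(F)F)cc1` gives 440000 nM. Compound 2 `O=C(CCCCCCNC(=O)C(O)(O)C(F)(F)F)Nc1ccc(Br)cc1` gives 100000 nM. Compound 3 `O=C(CCCCCCNC(=O)C(O)(O)C(F)(F)F)Nc1ncc(-c2ccccc2)s1` gives 350000 nM. Among the measured compounds shown here, compound 2 thus stands lowest of the three: compound 3 lies a 4.4-fold lower number from compound 1 to compound 2 (0.64 log units; beyond the scatter) apart from compound 1 on the other side, and the values of compound 2 and compound 3 show a gap beyond the scatter, though no single-point step connects them.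

Compound 4 `O=C(CCCCCCNC(=O)C(O)(O)C(F)(F)F)Nc1ccc(-c2ccccc2)cc1` is not yet measured. Its change from compound 2 is phenyl in place of bromo on an aromatic carbon. For the measured compounds named here, the only measured step at the same place is a 4.4-fold lower number from compound 1 to compound 2 (0.64 log units; beyond the scatter), which shows that the cap substituent does move the number here. Compound 3 carries a phenyl on a different core and gives a higher number than compound 2, but the two differ in more than one place, so it bears only loosely. A small to modest drop in this assay is expected for compound 4, with wide uncertainty. The expected step is a 1.7-fold lower number from compound 2 to compound 4 (0.22 log units; within the scatter). Compound 4 is estimated at 60000 nM, within 20000 nM to 200000 nM.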

Compound 4, half-maximal inhibitory concentration: 38000 nM
Compound 4: middle estimate off by 1.6-fold (0.20 log units), on the high side, within the range that was stated.
By their numbers in this assay, from the lowest: compound 4; then compound 2; then compounds 3 and 1 (each within the scatter of the next).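

Para to a large group, phenyl in place of bromo gives a 2.6-fold lower number from compound 2 to compound 4 (0.42 log units; beyond the scatter) and phenyl in place of methoxy gives a 12-fold lower number from compound 1 to compound 4 (1.06 log units; beyond the scatter), so this position accepts a whole added aromatic ring of six carbons in this assay and the number falls further than it did with bromo. Across the three groups at this place the order from the lowest number is phenyl, bromo, methoxy, with every step between them beyond the scatter. Nothing at hand explains this order.

On these data alone, it remains open whether the number keeps falling with a larger aromatic group here, such as naphthyl, or how an amine or a carboxylic acid at this place would compare. Also open, as far as these compounds go, is whether the phenyl step holds with a longer chain in the linker.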